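Chloro for fluoro on the benzyl group: toward compound 4

The source may report more compounds than this note shows. Statements on the series, on what has been measured and on what is new or still open speak of the compounds shown alone.

Measured compounds:
compound 1 `COc1ccc(/C=C(\C(=O)c2ccc(Br)cc2)S(=O)(=O)Cc2ccc(Cl)cc2)cc1`: 25000 nM
compound 2 `COc1ccc(/C=C(\C(=O)c2ccc(Br)cc2)S(=O)(=O)Cc2ccc(F)cc2)cc1`: 25000 nM
compound 3 `Cc1ccsc1/C=C(/SCc1ccc(F)cc1)C(=O)c1ccc(Br)cc1`: 50000 nM

In a functional assay on DU-145 cells (Homo sapiens) for inhibition, read by trypan blue exclusion, with a stated time of 96 h (on this read-out higher numbers stand for weaker inhibition of growth and lower numbers for stronger inhibition of growth), compound 1 gives 25000 nM and compound 2 gives 25000 nM. Among the measured compounds shown here, the single change between them is chloro in place of fluoro on an aromatic carbon; the step that results is no change at the digits printed from compound 2 to compound 1 (within the scatter). Compound 3 in this assay gives 50000 nM; the difference between the core of compound 3 and the core of compound 2 is not broken down here, and the two values are within the scatter of each other.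

Compound 4 `Cc1ccsc1/C=C(/SCc1ccc(Cl)cc1)C(=O)c1ccc(Br)cc1` is compound 3 with chloro in place of fluoro on an aromatic carbon. The place is described in the same words as for the step from compound 2 to compound 1, so this is the same change on a different core. Because no change at the digits printed from compound 2 to compound 1 (within the scatter) showed no movement, the step of a 1.1-fold lower number from compound 3 to compound 4 (0.05 log units; within the scatter) is expected to be small. Compound 4 is therefore estimated at 45000 nM in this assay, expected to lie between 20000 nM and 100000 nM.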

Compound 4, concentration for 50% growth inhibition: 25000 nM
Beside the measured number, compound 4's estimate is 1.8-fold (0.26 log units) above it; measured number inside the range.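

In this assay, chloro in place of fluoro on the benzyl group gives a 2.0-fold lower number from compound 3 to compound 4 (0.30 log units; within the scatter), and the same change can now be read on two cores: the same change on two cores in this assay, no change at the digits printed (within the scatter) from compound 2 to compound 1 and a 2.0-fold lower number (0.30 log units; within the scatter) from compound 3 to compound 4, 2.0-fold (0.30 log units) apart, within the scatter of two such steps
In this series, then, the swap from 4-fluorobenzyl to 4-chlorobenzyl carries from one core to the other without a difference that can be told from the scatter, and neither pair separates the two halogens. This does not show that the change is without effect on every core, as two pairs are a thin base for any rule and a small step would stay hidden within the scatter.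

The compounds shown leave open whether anything other than these two halogens in the same place, such as an amine, a carboxylic acid or a longer chain, would move the number beyond the scatter. They also leave open whether the benzyl group itself is needed, as every compound here carries one.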